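Chloro for trifluoromethyl on an aromatic carbon

The compounds below may be only part of what the source reports. "The series", "measured", "known", "first", "only" and "open" are said of these compounds alone.

Compound 2 `COc1cc(OC)c(OC)cc1/C=C/COC(=O)/C=C/c1ccccc1C(F)(F)F` is a close relative of compound 1 `COc1ccccc1/C=C/C(=O)OC/C=C/c1cc(OC)c(OC)cc1OC`; the two differ only by trifluoromethyl in place of methoxy on an aromatic carbon. In a functional assay on the whole organism (strain Kunming) with Mus musculus as the target, with a stated time of 0.5 h, at a dose of 300 mg/kg by the intraperitoneal route (on this read-out lower numbers stand for a stronger effect and higher numbers for a weaker effect at the one dose given), compound 1 gives 100%, and in this assay compound 2 gives 100%. Within the data shown here, the one recorded step is no change at the digits printed from compound 1 to compound 2 (within the scatter). On these numbers compound 2 stands level with compound 1 at the digits shown, within the scatter, and no order between the two can be read.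

Compound 3 `COc1cc(OC)c(OC)cc1/C=C/COC(=O)/C=C/c1ccccc1Cl` carries the change (chloro in place of trifluoromethyl on an aromatic carbon). Among the measured compounds shown here, the only measured step that bears on it is the earlier exchange at the same aromatic carbon, no change at the digits printed from compound 1 to compound 2 (within the scatter), which was flat. Nothing in the two measured compounds separates one group at this position from another, so for the step of no change at the digits printed from compound 2 to compound 3 (within the scatter) no movement beyond the scatter is expected in this assay. Compound 3 is therefore expected to give about 100% in this assay, with an estimated range from 88% to 100%.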

Compound 3, a percentage reported as activity, at one dose (the size of the read-out at that dose, not a potency): 100%
Estimate against measurement, compound 3: no gap at the digits printed; the measured number falls inside the stated range.
By their numbers in this assay, from the lowest: compounds 1, 2 and 3 (each within the scatter of the next).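

At this aromatic carbon, ortho to a large group, chloro in place of trifluoromethyl gives no change at the digits printed from compound 2 to compound 3 (within the scatter) in this assay, so a third group now joins the flat record at this position. The direct exchange of methoxy for chloro gives no change at the digits printed from compound 1 to compound 3 (within the scatter) as well, which means that methoxy, trifluoromethyl and chloro at this carbon show no order among them in this read-out, at this one dose and time. No measurement on hand offers an account of why the read-out stays level across these three groups.

From the compounds shown here alone, whether an amine, a carboxylic acid or a hydroxyl group on this aromatic carbon would shift the read-out beyond the scatter remains open, as does the effect of chloro on another carbon of the same ring. Going by these compounds, with all three compounds level at a single dose, it also remains open whether they would separate at other doses or at other times after dosing.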